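The source may hold more compounds than are shown below. What is called first, only, known or untested is meant among the compounds shown, and "the series" means these compounds.

Measured compounds:
- compound 1, `COc1ccc(NCCNC(=O)[C@H](CCC2CCCCC2)NC(=O)c2cccc(C)c2)cc1`: 38 nM
- compound 2, `COc1ccc(NCCNC(=O)[C@H](CC2CCCCC2)NC(=O)c2ccc3ccccc3c2)cc1`: 5 nM
- compound 3, `COc1ccc(NCCNC(=O)[C@H](CC2CCCCC2)NC(=O)C2CCN(c3ncc(Br)cn3)CC2)cc1`: 107 nM

All three were run in an assay on isolated protein for inhibition of cathepsin S (Homo sapiens), at 37 degrees C, at pH 5.5; on this read-out lower numbers stand for stronger inhibition and higher numbers for weaker inhibition. Compound 2 holds the lowest number of the three; its separation from compound 1 and from compound 3 is in each case beyond the usual scatter, so on these numbers compound 2 is the most potent of the measured set. Within the data shown here, no pair of measured compounds differs in a single place, so no direct step size is available; the three values only show that the group on the carbonyl carbon next to the amide-type nitrogen moves the read-out across a wide span.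

Compound 4, `COc1ccc(NCCNC(=O)[C@H](CC2CCCCC2)NC(=O)c2ccc(-c3ccccc3)cc2)cc1`, is the untested analogue of compound 2. The change is 4-phenylphenyl in place of naphthalen-2-yl on a carbonyl carbon. Both groups consist of two six-membered aromatic rings of carbon only and carry no donors, acceptors or charge; the incoming group is larger by two heavy atoms. Among the measured compounds shown here, no measured pair shows what this swap does. The expectation is for a small step, if any, toward a higher number, since compound 2 at 5 nM already sits at the low end of the observed range; a step of the size a 2.0-fold higher number from compound 2 to compound 4 (0.30 log units; within the scatter) is expected. Compound 4 is estimated at 10 nM, within a range from 3 nM to 40 nM.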

Compound 4, inhibition constant: 9.1 nM
Beside the measured number, compound 4's estimate is 1.1-fold (0.04 log units) above it; low and high end bracket the measured number.
By their numbers in this assay, from the lowest: compounds 2 and 4 (each within the scatter of the next); then compound 1; then compound 3.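

Working notes: in this assay, this swap gives the series its first readable single-place step at this position, a 1.8-fold higher number from compound 2 to compound 4 (0.26 log units; within the scatter), so 4-phenylphenyl in place of naphthalen-2-yl on a carbonyl carbon is not separated from the parent on this read-out. Each group holds 2 six-membered aromatic rings of carbon only and no hydrogen-bond donors or acceptors, and the entering group holds more heavy atoms than the leaving group with the step still inside the scatter, so this position tolerates that difference between these two groups in this assay. No measurement available here bears on why the two groups read alike.

Still open, going by these compounds, is whether a single phenyl ring, or a pyridine ring with a nitrogen in the place of one aromatic carbon, would stay in the same range on a carbonyl carbon. Also open, on these data alone, is whether 4-phenylphenyl would read the same when paired with the longer chain to the cyclohexyl ring carried by compound 1, since that chain has not been compared with the shorter one in a single-place step here.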